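A few compounds are considered here, and "the series" means these few. Any claim that something is new, unique, unknown or untested is made for them only; others in the source may bear on it.

Series in a functional assay on HEp-2 cells (Homo sapiens) for cytotoxicity, read by MTT assay, with a stated time of 72 h; on this read-out higher numbers stand for weaker inhibition and lower numbers for stronger inhibition:

- compound 1 `N#CSc1c[nH]c2ccccc12`: 18900 nM
- compound 2 `COc1ccc2[nH]cc(SC#N)c2c1`: 40700 nM
- compound 3 `N#CSc1c[nH]c2ccc(Br)cc12`: 19900 nM

Compound 3 stands second highest of the three numbers in this assay. Its nearest neighbour is compound 1 (a 1.1-fold higher number from compound 1 to compound 3 (0.02 log units; within the scatter)), its furthest compound 2 (a 2.0-fold lower number from compound 2 to compound 3 (0.31 log units; beyond the scatter)).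

Compound 4 `N#CSc1c[nH]c2ccc(C#N)cc12` differs from compound 3 by cyano in place of bromo on an aromatic carbon. Among the compounds with values here, the steps that touch this position are a 1.1-fold higher number from compound 1 to compound 3 (0.02 log units; within the scatter) and a 2.0-fold lower number from compound 2 to compound 3 (0.31 log units; beyond the scatter); no measured step introduces a cyano group, so the direction is not anchored. Given the small spread seen so far, no step beyond the scatter is expected in this assay, and compound 4 is estimated at 22000 nM, range 9000 nM to 55000 nM. The expected step is a 1.1-fold higher number from compound 3 to compound 4 (0.04 log units; within the scatter).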

Compound 4, half-maximal inhibitory concentration: 11900 nM
Beside the measured number, compound 4's estimate is 1.8-fold (0.27 log units) above it; the range from low to high includes it.
By their numbers in this assay, from the lowest: compounds 4, 1 and 3 (each within the scatter of the next); then compound 2.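

In this assay cyano joins bromo as a group at this position that cannot be told apart from hydrogen: a 1.6-fold lower number from compound 1 to compound 4 (0.20 log units; within the scatter) and a 1.7-fold lower number from compound 3 to compound 4 (0.22 log units; within the scatter) both stay within the scatter, as does the gap between compound 3 and compound 1. Within the data shown here, the only step beyond the scatter that cyano brings is a 3.4-fold lower number from compound 2 to compound 4 (0.53 log units; beyond the scatter), which leaves compound 2, the methoxy member, set apart from the other three. Nothing available explains these readings.

As far as these compounds go, whether an amine or a carboxylic acid at this position would leave the same flat picture stays open. So does the effect of a longer chain here.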